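Ester chain extension and cytotoxicity in one series

The source may report more compounds than this note shows. Statements on the series, on what has been measured and on what is new or still open speak of the compounds shown alone.

Three measured compounds share one core and differ only in the ester chain. Compound 1 `CCCCCCOC(=O)CCC(=O)N1CCN(CCCOc2cc3c(Nc4ccc(F)c(Cl)c4)ncnc3cc2OC)CC1` gives 89.3% in a functional assay on A549 cells (Homo sapiens) for cytotoxicity, read by MTT assay, with a stated time of 24 h, tested at 10 uM; on this read-out higher numbers stand for a weaker effect at the one concentration tested and lower numbers for a stronger effect; compound 2 `CCCCCCCOC(=O)CCC(=O)N1CCN(CCCOc2cc3c(Nc4ccc(F)c(Cl)c4)ncnc3cc2OC)CC1` gives 89.1%; compound 3 `CCCCCCCCCCCCCCOC(=O)CCC(=O)N1CCN(CCCOc2cc3c(Nc4ccc(F)c(Cl)c4)ncnc3cc2OC)CC1` gives 100%. The change from compound 1 to compound 2 is methyl in place of hydrogen on a saturated chain carbon, six bonds along the chain from an oxygen next to a carbonyl group and produced a number 0.2 percentage points lower from compound 1 to compound 2 (within the scatter). The larger change octyl in place of hydrogen on a saturated chain carbon, six bonds along the chain from an oxygen next to a carbonyl group produced a number 10.7 percentage points higher from compound 1 to compound 3 (beyond the scatter), and a number 10.9 percentage points higher from compound 2 to compound 3 (beyond the scatter); compound 3 therefore stands highest of the three, both gaps beyond the scatter.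

Compound 4 `CCCCCCCCCCCCCCCOC(=O)CCC(=O)N1CCN(CCCOc2cc3c(Nc4ccc(F)c(Cl)c4)ncnc3cc2OC)CC1` is not yet measured. It differs from compound 3 by methyl in place of hydrogen on a saturated chain carbon, ten or more bonds along the chain from an oxygen next to a carbonyl group. For the measured compounds named here, this is the same kind of change as the one from compound 1 to compound 2, but the place differs: in the pair from compound 3 to compound 4 the methyl enters further out along the chain than in the pair from compound 1 to compound 2. The cores of the two pairs differ by octyl in place of hydrogen on a saturated chain carbon, six bonds along the chain from an oxygen next to a carbonyl group.

Since the one-carbon step gave a number 0.2 percentage points lower from compound 1 to compound 2 (within the scatter), a step of similar size is expected here, a number 1 percentage points lower from compound 3 to compound 4 (within the scatter), for compound 4. The expected value for compound 4 in this assay is 99%, ranging from 90% to 106%.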

Compound 4, a percentage reported as activity, at one concentration (the size of the read-out at that concentration, not a potency): 92%
For compound 4 the middle estimate is 7 percentage points above the measured one; the range from low to high includes it.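

The methyl step carries across from the shorter ester chain to the longer one in this assay, with a number 8 percentage points lower from compound 3 to compound 4 (within the scatter) and no difference between the two cores: the same change on two cores in this assay, a number 0.2 percentage points lower (within the scatter) from compound 1 to compound 2 and a number 8 percentage points lower (within the scatter) from compound 3 to compound 4, 7.8 percentage points apart, within the scatter of two such steps. For the compounds shown here, the octyl step also shows no difference between its two cores, even though only one of the pair lies beyond the scatter, and the longest chain shows a number 2.9 percentage points higher from compound 2 to compound 4 (within the scatter) and a number 2.7 percentage points higher from compound 1 to compound 4 (within the scatter): the same change on two cores in this assay, a number 10.7 percentage points higher (beyond the scatter) from compound 1 to compound 3 and a number 2.9 percentage points higher (within the scatter) from compound 2 to compound 4, 7.8 percentage points apart, within the scatter of two such steps. This shows agreement within the scatter on four straight-chain esters at one concentration; it does not show a fixed size for a one-carbon step or a trend with chain length, as compound 3 stands apart from compound 1 and compound 2 while compound 4 does not.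

The compounds shown leave open how chains of intermediate length between those of compound 2 and compound 3 behave. They also leave open whether a branched chain, or a carboxylic acid in place of the ester, would give a stronger effect in this assay.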